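Cyclic amines at the pyridine position: a third compound

The source may report more compounds than this note shows. Statements on the series, on what has been measured and on what is new or still open speak of the compounds shown alone.

Measured so far:
compound 1 `CC(C(=O)NCc1ccc(C(F)(F)F)nc1NCc1ccccc1)c1ccc(NS(C)(=O)=O)c(F)c1` gives 15.8 nM in a functional assay on CHO-K1 cells for antagonist activity at transient receptor potential cation channel subfamily V member 1 (Homo sapiens), read by FLIPR; a higher number here means a weaker inhibitor, a lower number a stronger inhibitor
compound 2 `C[C@H](C(=O)NCc1ccc(C(F)(F)F)nc1N1CCC(c2ccccc2)CC1)c1ccc(NS(C)(=O)=O)c(F)c1` gives 0.3 nM in this assay

Of the two measured compounds, compound 1 has the higher number in this assay, and compound 2 stands well below it, a difference that lies beyond the usual scatter. Going by the values given here, no single-point step between the two is recorded, so only their two values can be compared.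

Compound 3 `CC(C(=O)NCc1ccc(C(F)(F)F)nc1N1CCC(O)CC1)c1ccc(NS(C)(=O)=O)c(F)c1` is not yet measured. It differs from compound 1 in one place: 4-hydroxypiperidin-1-yl in place of benzylamino on an aromatic carbon. Compound 2 shows that a cyclic amine on this carbon is compatible with a very strong inhibitor, but compound 2 carries a phenyl on its ring where compound 3 carries a hydroxyl, and the two cannot be equated. For compound 3 the step of a 1.6-fold higher number from compound 1 to compound 3 (0.20 log units; within the scatter) is expected to be small, if anything toward a weaker inhibitor, and may not exceed the scatter. The expected value for compound 3 is therefore 25 nM, with a likely range from 6 nM to 100 nM.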

Compound 3, inhibition constant: "not active" (no number reported)
The entry for compound 3 holds no number, and the estimate cannot be compared.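

Going by these compounds alone, compound 3 is recorded as "not active" in this assay with no number reported, so no step from compound 1 to compound 3 can be read. Nothing shown accounts for this result. The compounds shown leave open how large the gap between compound 1 and compound 3 is.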